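Mdm2 binders: extending the benzamido group of compound 3

This account rests on a few compounds, and the source may have more. Where it says the series, first, only, none or still open, it means among the compounds named here.

Measured so far in an assay for displacement of a labelled ligand from E3 ubiquitin-protein ligase Mdm2 (Homo sapiens), read by fluorescence polarization, with a stated time of 30 min; a lower number here means a stronger inhibitor, a higher number a weaker inhibitor:
compound 1 `CC(C)COc1ccc(-c2cc(C(=O)O)nn2-c2ccccc2)cc1` gives 7420 nM
compound 2 `CCOc1ccc(-c2cc(C(=O)O)nn2-c2ccc(Oc3ccccc3)cc2)cc1` gives 1030 nM
compound 3 `CCOc1ccc(-c2c(NC(=O)c3ccccc3)c(C(=O)O)nn2-c2ccc(Oc3ccccc3)cc2)cc1` gives 1130 nM

Compound 3 stands second highest of the three numbers; compound 2 is its nearest neighbour, within the scatter, and compound 1 is furthest, beyond it. Within the data shown here, the single one-place step measured, a 1.1-fold higher number from compound 2 to compound 3 (0.04 log units; within the scatter), shows that attaching the benzamido group changed little.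

Compound 4 `CCOc1ccc(-c2c(NC(=O)c3ccc(OC(C)C)cc3)c(C(=O)O)nn2-c2ccc(Oc3ccccc3)cc2)cc1` carries isopropoxy in place of hydrogen on an aromatic carbon. Among the measured compounds shown here, no measured step touches the benzoyl group itself, so there is no direct precedent; the related step of a 1.1-fold higher number from compound 2 to compound 3 (0.04 log units; within the scatter) was flat. The expectation for this assay is therefore a small change, if any, estimated as a 1.4-fold lower number from compound 3 to compound 4 (0.15 log units; within the scatter).

Compound 4 is estimated at 800 nM, with a range from 300 nM to 2500 nM.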

Compound 4, inhibition constant: 301 nM
For compound 4 the middle estimate is 2.7-fold (0.42 log units) above the measured one; the range from low to high includes it.
By their numbers in this assay, from the lowest: compound 4; then compounds 2 and 3 (each within the scatter of the next); then compound 1.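

Isopropoxy in place of hydrogen on an aromatic carbon of the benzoyl ring, para to a large group, gives a 3.8-fold lower number from compound 3 to compound 4 (0.57 log units; beyond the scatter) in this assay. Attaching the benzamido group itself was flat (a 1.1-fold higher number from compound 2 to compound 3 (0.04 log units; within the scatter)), so this is the first step in the series beyond the scatter at the benzamido group, and the outer ring responds to substitution. No measurement on hand accounts for the gain.

One substituent at one place defines no trend. From the compounds shown here alone, whether an amine, a longer chain or a carboxylic acid at this place would match isopropoxy remains open.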